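The compounds below may be only part of what the source reports. "The series", "measured", "known", "first", "only" and "open" are said of these compounds alone.

Of the compounds shown here, three built on one shared core have been tested in an assay on lysate for inhibition of 6-phosphofructo-2-kinase/fructose-2,6-bisphosphatase 3 (Homo sapiens), with stated times of 0.5 min and 45 min; on this read-out lower numbers stand for stronger inhibition and higher numbers for weaker inhibition. Compound 1 `Cn1ccc2ccc(-c3cc(Nc4ccccc4S(=O)(=O)N4CCOCC4)cc4nccnc34)cc21` carries a morpholin-4-yl group on its sulfonyl sulfur, and in this assay compound 1 gives 2640 nM. Compound 2 `CN(Cc1cncnc1)S(=O)(=O)c1ccccc1Nc1cc(-c2ccc3ccn(C)c3c2)c2nccnc2c1` differs from it only in the group on that sulfur, and in this assay compound 2 reaches only a limit of the assay, > 100000 nM, which is the limit of > 100000 nM in this assay, at which 1 of the 3 values shown sits. The step of an at least 37-fold higher number from compound 1 to compound 2 (1.57 log units; beyond the scatter) is therefore a large loss, and its full size is hidden by the limit.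

Compound 3 `Cn1ccc2ccc(-c3cc(Nc4cnccc4C(=O)NCc4cncnc4)cc4nccnc34)cc21` replaces the whole sulfonamide arm by a carboxamide bearing a (pyrimidin-5-yl)methyl group; in this assay compound 3 gives 49500 nM, the higher of the two numbers that were read, compound 1 giving the lower one.

Compound 4 `CC(=O)N1CCC(NC(=O)c2ccncc2Nc2cc(-c3ccc4ccn(C)c4c3)c3nccnc3c2)CC1` is compound 3 with 1-acetylpiperidin-4-yl in place of (pyrimidin-5-yl)methyl on an amide-type nitrogen. Within the data shown here, only one measured step bears on this: an at least 37-fold higher number from compound 1 to compound 2 (1.57 log units; beyond the scatter), where a group containing (pyrimidin-5-yl)methyl entered in place of a six-membered non-aromatic ring and the number rose sharply. Compound 4 moves the opposite way, on a different arm, so a modest move toward a lower number is expected, estimated as a 3.3-fold lower number from compound 3 to compound 4 (0.52 log units; beyond the scatter). Compound 4 is expected to give about 15000 nM, within a range from 3000 nM to 80000 nM.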

Compound 4, half-maximal inhibitory concentration: 31300 nM
The estimate for compound 4 lay 2.1-fold (0.32 log units) below the measured number, within the range that was stated.
By their numbers in this assay, from the lowest: compound 1; then compounds 4 and 3 (each within the scatter of the next). At a limit, above all of these: compound 2.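

In this assay, a 1.6-fold lower number from compound 3 to compound 4 (0.20 log units; within the scatter), so a six-membered aromatic ring with two hetero atoms and a six-membered non-aromatic ring carrying an acetyl group cannot be told apart on this amide-type nitrogen. Among these compounds, this is the first view of a change at this place alone, and it shows that a larger group with a different ring and one extra double bond outside aromatic rings still leaves the number within the usual scatter. The large step seen earlier, an at least 37-fold higher number from compound 1 to compound 2 (1.57 log units; beyond the scatter), concerned the group on a sulfonyl sulfur in a different arm, and it does not carry over to this nitrogen; nothing measured here accounts for the two amide groups reading alike.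

On these data alone, two groups at one place cannot show how much freedom this nitrogen really allows, so it remains open whether a free amine, a carboxylic acid or a longer chain in place of these rings would move the number beyond the scatter. As far as these compounds go, it also remains open whether 1-acetylpiperidin-4-yl would behave the same way on the sulfonyl sulfur, where the change in group mattered far more.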